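Urea series on human kidney cells: a pyridine for an aniline

The source may hold more compounds than are shown below. What is called first, only, known or untested is meant among the compounds shown, and "the series" means these compounds.

Compound 1 `COc1ccc(NC(=O)Nc2cc(C)nc3ccccc23)cc1` gives in an ADME assay on HEK293 cells (Homo sapiens) for cytotoxicity, with a stated time of 72 h (a higher number here means that more compound is needed for the effect, a lower number that less compound is needed), only the limit > 25000 nM.
Compound 2 `Cc1cc(NC(=O)Nc2ccc(C(=O)O)cc2)c2ccccc2n1` gives in this assay only the limit > 25000 nM.
Compound 3 `Cc1cc(NC(=O)Nc2ccc(N)cc2)c2ccccc2n1` gives in this assay only the limit > 25000 nM.

All three compounds share one core and differ only in the group on the second ring. Each value is a limit, not a number, so the steps a step that the two limits leave unreadable from compound 1 to compound 2, a step that the two limits leave unreadable from compound 1 to compound 3 and a step that the two limits leave unreadable from compound 2 to compound 3 cannot be sized; the common feature is the limit of > 25000 nM in this assay, at which 3 of the 3 values shown sit. Compound 4 `Cc1cc(NC(=O)Nc2cccnc2)c2ccccc2n1` carries the change (pyridin-3-yl in place of 4-aminophenyl on an amide-type nitrogen). With every earlier compound at the limit, no step beyond the scatter can be read, and compound 4 is expected to sit at that limit too, a step that the limit leaves unreadable from compound 3 to compound 4. The estimate for compound 4 is 30000 nM, from 15000 nM to 100000 nM.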

Compound 4, half-maximal effective concentration: > 25000 nM
Compound 4: no number, only a limit (the forecaster's own chance of this, stated with the estimate: 85%); the middle value does not contradict the limit.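

Compound 3 and compound 4 both give only a limit, so the step between them cannot be read, and no new step emerges: the limit of > 25000 nM in this assay, at which 4 of the 4 values shown sit.

The compounds shown leave open what concentration any of them needs for the effect in this assay, and whether swapping these groups changes it at all.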